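Methyl on a Ring Nitrogen, Tested Across Two Cores

The compounds below may be only part of what the source reports. "The series", "measured", "known", "first", "only" and "open" are said of these compounds alone.

Of the compounds shown here, three have been measured in a functional assay on HL-60 cells (Homo sapiens) for inhibition; a lower number here means a stronger inhibitor, a higher number a weaker inhibitor. Compound 1, `COc1cc(/C=C\c2c[nH]c3ccccc23)cc(OC)c1OC`, gives 3230 nM in this assay. Compound 2, `COc1cc(/C=C\c2cn(C)c3ccccc23)cc(OC)c1OC`, gives 3090 nM in this assay. The step of a 1.0-fold lower number from compound 1 to compound 2 (0.02 log units; within the scatter) comes from methyl in place of hydrogen on an aromatic nitrogen

Compound 3, `COc1cc(/C=C/c2ccc3[nH]ccc3c2)cc(OC)c1OC`, is built from the same atoms as compound 1, joined differently; the difference between the two cores is not broken down here. In this assay compound 3 gives 380 nM, the lowest of the three numbers, and its gaps to compound 2 and to compound 1 both lie beyond the scatter.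

Compound 4, `COc1cc(/C=C/c2ccc3c(ccn3C)c2)cc(OC)c1OC`, has not yet been measured. It differs from compound 3 by methyl in place of hydrogen on an aromatic nitrogen

For the measured compounds named here, this is the same kind of change as the one from compound 1 to compound 2, though not the same: in that earlier pair the aromatic nitrogen sits two ring bonds from the ring atom that bears a large group, whereas no such note applies around the place in compound 3.

The size of the new step is estimated to be small, because the step of a 1.0-fold lower number from compound 1 to compound 2 (0.02 log units; within the scatter) stayed within the scatter, so the step of a 1.1-fold higher number from compound 3 to compound 4 (0.02 log units; within the scatter) is expected to be of that order. Compound 4 is therefore estimated at 400 nM, with a likely range from 150 nM to 1100 nM.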

Compound 4, half-maximal inhibitory concentration: 27 nM
Beside the measured number, compound 4's estimate is 15-fold (1.17 log units) above it; measured number below the stated range.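

What this series shows is that the same small change need not have the same effect on a different core. In this assay, methyl in place of hydrogen on an aromatic nitrogen changes the number by clearly different amounts on the two cores: the same change on two cores in this assay, a 1.0-fold lower number (0.02 log units; within the scatter) from compound 1 to compound 2 and a 14-fold lower number (1.15 log units; beyond the scatter) from compound 3 to compound 4, 13-fold (1.13 log units) apart, beyond the scatter of two such steps. On the core of compound 1 the change makes no difference that can be told from the scatter, whereas the other core gives a 14-fold lower number from compound 3 to compound 4 (1.15 log units; beyond the scatter), so a flat result on one core was no guide to the other.

For the compounds shown here, this does not show which feature of the cores decides the outcome, since the two cores are joined differently and only one pair has been measured on each, and two pairs set no rule for any further core.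

The compounds shown leave open how a group other than methyl on that nitrogen, such as ethyl, a longer chain or an acetyl group, would behave on either core. They also leave open whether the large step on the core of compound 3 would reappear with a carboxylic acid or an amine elsewhere on the molecule.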